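This account rests on a few compounds, and the source may have more. Where it says the series, first, only, none or still open, it means among the compounds named here.

Of the compounds shown here, three built on one shared core have been measured in a functional assay on DU-145 cells (Homo sapiens) for inhibition, read by MTT assay, with a stated time of 72 h; on this read-out higher numbers stand for weaker inhibition of growth and lower numbers for stronger inhibition of growth. Compound 1 `COc1ccc(CNC(=O)/C(C#N)=C/c2ccc[nH]2)cc1` gives only a limit in this assay, > 50000 nM, and the limit of > 50000 nM in this assay, at which 1 of the 3 values shown sits, is where that limit sits. Compound 2 `COc1ccc(CNC(=O)/C(C#N)=C/c2ccco2)cc1` gives 29000 nM in this assay. Compound 3 `COc1ccc(CNC(=O)/C(C#N)=C/c2ccc(C)o2)cc1` gives 39000 nM in this assay, the highest of the two numbers, with compound 2 nearest: a 1.3-fold higher number from compound 2 to compound 3 (0.13 log units; within the scatter). The two remaining steps, an at least 1.7-fold lower number from compound 1 to compound 2 (0.23 log units; that floor lies within the scatter) and an at least 1.2-fold lower number from compound 1 to compound 3 (0.10 log units; that floor lies within the scatter), each rest on a limit and give only a floor.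

Compound 4 `COc1ccc(CNC(=O)/C(C#N)=C/c2ccc(Cl)o2)cc1` has not yet been measured. It differs from compound 3 in one place: chloro in place of methyl on an aromatic carbon. The measured step that bears most closely on this change is the one in which methyl replaced hydrogen on an aromatic carbon, a 1.3-fold higher number from compound 2 to compound 3 (0.13 log units; within the scatter), a change that stayed within the scatter. The steps from compound 1 say little about the size of a change at that carbon, since they start from a limit. Compound 4 is therefore expected to show no step beyond the scatter in this assay, a 1.1-fold lower number from compound 3 to compound 4 (0.05 log units; within the scatter). Compound 4 is estimated at 35000 nM in this assay, between 12000 nM and 90000 nM.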

Compound 4, concentration for 50% growth inhibition: 12000 nM
For compound 4 the middle estimate is 2.9-fold (0.46 log units) above the measured one; low and high end bracket the measured number.
By their numbers in this assay, from the lowest: compound 4; then compounds 2 and 3 (each within the scatter of the next). At a limit, above all of these: compound 1.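

In this assay, the aromatic carbon next to the ring oxygen proves responsive to its substituent, with chloro in place of methyl (a 3.3-fold lower number from compound 3 to compound 4 (0.51 log units; beyond the scatter)) and chloro in place of hydrogen (a 2.4-fold lower number from compound 2 to compound 4 (0.38 log units; beyond the scatter)) both moving the number beyond the scatter. Methyl in place of hydrogen at this carbon had stayed within the scatter, so the earlier compounds gave no sign that a change here could matter, whereas compound 4 now separates from both compound 2 and compound 3. The change from 1H-pyrrol-2-yl to 5-chlorofuran-2-yl (an at least 4.1-fold lower number from compound 1 to compound 4 (0.61 log units; beyond the scatter)) is also the first step from compound 1 to clear the scatter, though it gives only a floor, resting on a limit: the limit of > 50000 nM in this assay, at which 1 of the 4 values shown sits.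

The compounds shown leave open whether the lower number is particular to chloro or extends to bromo, a nitrile or a trifluoromethyl at the same carbon. Also open, as far as these compounds go, is how an amine or a carboxylic acid at that carbon would read in this assay and whether any such group could reach a much lower number.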